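Branched to unsaturated: a side-chain change on compound 3

The source may hold more compounds than are shown below. What is called first, only, known or untested is meant among the compounds shown, and "the series" means these compounds.

Measured compounds and their values:
Compound 1 `CCCCn1c(Cc2cc(OC)c(OC)c(OC)c2)nc2c(N)nc(F)nc21` — in a functional assay on MCF7 cells (Homo sapiens) for antiproliferative activity (on this read-out lower numbers stand for stronger inhibition and higher numbers for weaker inhibition), compound 1 gives 24000 nM
Compound 2 `CCCCn1c(Cc2c(Br)c(OC)c(OC)c(OC)c2Br)nc2c(N)ncnc21` — compound 2 gives 30200 nM
Compound 3 `COc1cc(Cc2nc3c(N)ncnc3n2CC(C)C)cc(OC)c1OC` — compound 3 gives 97700 nM

All three share a core and differ at the chain on the ring nitrogen and at substituents on the two ring systems. Compound 3 stands at the highest number of the three, meaning the weakest inhibition; its nearest neighbour is compound 2, and compound 1 is furthest from it, both gaps lying beyond the usual scatter.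

Compound 4 `C/C=C/Cn1c(Cc2cc(OC)c(OC)c(OC)c2)nc2c(N)ncnc21` has not yet been measured. It is built from compound 3 by one change: prop-1-en-1-yl in place of isopropyl on a saturated chain carbon bound to an aromatic nitrogen. Going by the values given here, no measured pair shows this exact change, so the expected size of the step rests on the spread of the three numbers. Since compound 3 sits at the weak end and compound 1, with an unbranched chain, gives 24000 nM, a modest move toward stronger inhibition is expected, though it could also fall within the scatter. The step from compound 3 to compound 4 is estimated as a 2.4-fold lower number from compound 3 to compound 4 (0.39 log units; beyond the scatter). For compound 4 the expected value is 40000 nM, with a likely range from 12000 nM to 110000 nM.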

Compound 4, half-maximal inhibitory concentration: 51300 nM
Compound 4: the middle estimate sits 1.3-fold (0.11 log units) below what was measured; the range from low to high includes it.
By their numbers in this assay, from the lowest: compounds 1, 2, 4 and 3 (each within the scatter of the next, the first and the last beyond it).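

Going by these compounds alone, compound 3 and compound 4 form the only pair here that differs in one place, and in this assay it gives a 1.9-fold lower number from compound 3 to compound 4 (0.28 log units; within the scatter) with the step inside the usual scatter. Within the data shown here, at this chain on the ring nitrogen, then, prop-1-en-1-yl in place of isopropyl, which removes the branch and adds one double bond, leaves the read-out indistinguishable from repeat-measurement noise, something the earlier compounds, all differing in more than one place, could not show. No other measurement here helps to interpret this result.

Compound 1 and compound 2 each differ from compound 3 and compound 4 in more than one place, so the separate contributions of their chain and ring substituents remain unresolved. As far as these compounds go, whether a longer chain such as hexyl, or a chain ending in an amine or a carboxylic acid, would move the number beyond the scatter also remains open.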